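Isopropyl for cyclopropyl on the aromatic nitrogen: clearance notes

The source may report more compounds than this note shows. Statements on the series, on what has been measured and on what is new or still open speak of the compounds shown alone.

Measured so far in an ADME assay on microsomes from liver (Homo sapiens) for metabolic stability; on this read-out lower numbers stand for slow clearance and higher numbers for fast clearance:
Compound 1 `CC(=O)N1CC(Oc2cc(-c3cnnc4c3ncn4C(C)C)ccc2F)C1` gives < 8 mL.min-1.g-1 (a limit of the assay, not a number)
Compound 2 `CCn1cnc2c(-c3ccc(F)c(Oc4ccc(C#N)cn4)c3)cnnc21` gives 65 mL.min-1.g-1
Compound 3 `N#Cc1ccc(Oc2cc(-c3cnnc4c3ncn4C3CC3)ccc2F)nc1` gives 17 mL.min-1.g-1

Compound 3 holds the lower of the two actual numbers in this assay and compound 2 holds the higher, while compound 1 reports only a limit. Compound 4 `CC(C)n1cnc2c(-c3ccc(F)c(Oc4ccc(C#N)cn4)c3)cnnc21` has not yet been measured and has isopropyl in place of cyclopropyl on an aromatic nitrogen. For the measured compounds named here, the one measured step at this place is a 3.8-fold lower number from compound 2 to compound 3 (0.58 log units; beyond the scatter) with cyclopropyl in place of ethyl on an aromatic nitrogen. Compound 1 also carries isopropyl on an aromatic nitrogen, but it differs elsewhere and gives only a limit, so it sets no step size. Compound 4 returns to a group without a ring, as in compound 2, so a higher number is expected, with a size no larger than that of a 3.8-fold lower number from compound 2 to compound 3 (0.58 log units; beyond the scatter) in the measured step. The expected step is a 2.1-fold higher number from compound 3 to compound 4 (0.31 log units; beyond the scatter) and it would undo part of the measured change. For compound 4 the estimated value is 35 mL.min-1.g-1 with an expected range from 15 mL.min-1.g-1 to 80 mL.min-1.g-1 in this read-out.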

Compound 4, intrinsic clearance in microsomes: 38 mL.min-1.g-1
For compound 4 the middle estimate is 1.1-fold (0.04 log units) below the measured one; measured number inside the range.
By their numbers in this assay, from the lowest: compound 3; then compounds 4 and 2 (each within the scatter of the next). At a limit, below all of these: compound 1.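

In this assay, the change from cyclopropyl to isopropyl gives a 2.2-fold higher number from compound 3 to compound 4 (0.35 log units; beyond the scatter), so two groups with the same count of heavy atoms on this aromatic nitrogen, one with a three-membered ring and one with no ring, are separated beyond the scatter. Adding a methyl to the ethyl group gives a 1.7-fold lower number from compound 2 to compound 4 (0.23 log units; within the scatter), so ethyl and isopropyl are not separated, and among the three groups at this place only cyclopropyl stands apart, with compound 3 lowest in this small set. With isopropyl held constant, the first step read at the oxygen is an at least 4.7-fold higher number from compound 1 to compound 4 (0.67 log units; beyond the scatter), showing that the group there also moves the read-out, though the size of this step is open-ended, as compound 1 reports only a limit of the assay: the limit of < 8 mL.min-1.g-1 in this assay, at which 1 of the 4 values shown sits.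

The compounds shown do not tell whether a cyclobutyl group or a 2-methoxyethyl chain on the aromatic nitrogen would stand with cyclopropyl or with the open-chain groups. They also leave open whether the cyclopropyl step carries over with 1-acetylazetidin-3-yl on the oxygen.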